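Swapping Isopropyl for Nitro: From Compound 1 to Compound 4

A few compounds are considered here, and "the series" means these few. Any claim that something is new, unique, unknown or untested is made for them only; others in the source may bear on it.

Measured compounds:
compound 1, `Cc1cnc(Nc2ccc(C(C)C)cc2)nc1Nc1nc2ccccc2s1`: in a functional assay on HeLa cells (Homo sapiens) for antiproliferative activity, read by MTT assay, with a stated time of 48 h (on this read-out higher numbers stand for weaker inhibition and lower numbers for stronger inhibition), compound 1 gives > 50000 nM, a limit rather than a number.
compound 2, `Cc1ccc2nc(Nc3nc(Nc4ccc(S(N)(=O)=O)cc4)ncc3C)sc2c1`: compound 2 gives 3280 nM.
compound 3, `NS(=O)(=O)c1ccc(Nc2ncc(F)c(Nc3nc4ccccc4s3)n2)cc1`: compound 3 gives 4520 nM.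

Compound 1 stands at the limit of this assay; its reading, (the limit of > 50000 nM in this assay, at which 1 of the 3 values shown sits), tells only that it falls outside the measured range. Compounds 2 and 3 both return numbers inside that range, and the two values lie within the scatter of each other.

Compound 4, `Cc1cnc(Nc2ccc([N+](=O)[O-])cc2)nc1Nc1nc2ccccc2s1`, differs from compound 1 in one place: nitro in place of isopropyl on an aromatic carbon. Within the data shown here, no measured pair shares exactly this exchange, so the expected size of the step rests only on the spread of the values shown. Compounds 2 and 3 show that close relatives of compound 1 can give numbers inside the measured range. Compound 4 is therefore expected to come in near 15000 nM, with a plausible range from 3000 nM to 50000 nM. As a step, this estimate means an at least 3.3-fold lower number from compound 1 to compound 4 (0.52 log units; beyond the scatter) toward stronger inhibition, while a reading that again stops at the limit is expected to remain a real possibility.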

Compound 4, half-maximal inhibitory concentration: 34300 nM
Compound 4: the middle estimate sits 2.3-fold (0.36 log units) below what was measured; the range from low to high includes it.
By their numbers in this assay, from the lowest: compounds 2 and 3 (each within the scatter of the next); then compound 4. At a limit, above all of these: compound 1.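

In this assay, nitro in place of isopropyl on the aromatic carbon gives an at least 1.4-fold lower number from compound 1 to compound 4 (0.16 log units; that floor lies within the scatter), so a change at this place, para to a large group, is enough to bring the shared core off the limit. With the rest of the structure unchanged, compound 4 gives a readable 34300 nM, which shows that this one exchange can decide whether a number is obtained at all. The size of the step is only a floor, and that floor lies within the scatter, because compound 1 stands at a limit: the limit of > 50000 nM in this assay, at which 1 of the 4 values shown sits.

The compounds shown leave open how an amine or a carboxylic acid on this same aromatic carbon would read in this assay. They also leave open how large the true step from isopropyl to nitro is.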